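Iodo for Ethynyl: What to Expect for Compound 4

The source may hold more compounds than are shown below. What is called first, only, known or untested is meant among the compounds shown, and "the series" means these compounds.

Of the compounds shown here, three have been measured in a functional assay on K562 cells (Homo sapiens), read by MTT assay, with a stated time of 72 h; on this read-out lower numbers stand for stronger inhibition and higher numbers for weaker inhibition. In this assay compound 1 `C#Cc1cn([C@@H]2O[C@H](CO)[C@@H](O)[C@H]2O)c2nc(C)nc(N)c12` gives 3290 nM. Compound 2 `Cc1nc(N)c2c(I)cn([C@@H]3O[C@H](CO)[C@@H](O)[C@H]3O)c2n1` differs from compound 1 in one place only, (iodo in place of ethynyl on an aromatic carbon). In this assay compound 2 gives 1110 nM, so the step is a 3.0-fold lower number from compound 1 to compound 2 (0.47 log units; beyond the scatter). Compound 3 `C#Cc1cn([C@@H]2O[C@H](CO)[C@@H](O)[C@H]2O)c2ncnc(OC)c12` sits on a different core and keeps the ethynyl group; in this assay compound 3 gives 380 nM, the lowest of the three numbers, with compound 2 nearest to it and compound 1 furthest away. The difference between the core of compound 3 and the core of compound 1 is not broken down here.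

Compound 4 `COc1ncnc2c1c(I)cn2[C@@H]1O[C@H](CO)[C@@H](O)[C@H]1O` has not yet been measured. It relates to compound 3 exactly as compound 2 relates to compound 1: iodo in place of ethynyl on an aromatic carbon. The surroundings of the place are described in the same words for both pairs, so this is the same change, made once before, now carried onto the core of compound 3.

The expectation rests on that single earlier step, because the change produced a 3.0-fold lower number from compound 1 to compound 2 (0.47 log units; beyond the scatter) and nothing in the data speaks against a similar gain on the second core. The step from compound 3 to compound 4 is therefore estimated as a 2.7-fold lower number from compound 3 to compound 4 (0.43 log units; beyond the scatter). Compound 4 is expected to give about 140 nM in this assay, with a likely range from 50 nM to 450 nM. Going by the values given here, the range is wide: the change has only one precedent, a 3.0-fold lower number from compound 1 to compound 2 (0.47 log units; beyond the scatter), and the core is different.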

Compound 4, half-maximal inhibitory concentration: 14800 nM
Beside the measured number, compound 4's estimate is 110-fold (2.02 log units) below it, and the stated range ends below it.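

Iodo in place of ethynyl on an aromatic carbon now gives a 39-fold higher number from compound 3 to compound 4 (1.59 log units; beyond the scatter) in this assay, so the change that lowered the number on the core of compound 1 raises it sharply on the other core. Set side by side, the two steps disagree in direction and size, and the result on one core proved no safe guide to the result on the other in this series: the same change on two cores in this assay, a 3.0-fold lower number (0.47 log units; beyond the scatter) from compound 1 to compound 2 and a 39-fold higher number (1.59 log units; beyond the scatter) from compound 3 to compound 4, 120-fold (2.06 log units) apart, beyond the scatter of two such steps. This does not show why the cores part ways: they differ in ways not broken down here, and two pairs cannot reveal which part of the core turns the result around or whether either pair is the more typical one.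

From the compounds shown here alone, it remains open whether the methoxy group of compound 3 or the missing methyl group matters most, and a core carrying methoxy together with methyl would help to separate the two. Going by these compounds, it also remains open how other groups would behave on the same aromatic carbon, where a bromo group, a nitrile or a longer alkyne chain could show whether the ethynyl or the iodo compound on this core is the unusual one.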